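The source may report more compounds than this note shows. Statements on the series, on what has been measured and on what is new or still open speak of the compounds shown alone.

Measured compounds:
- compound 1, `COc1ccc(C(c2ccc(OC)c(OC)c2)[C@H](C)[C@@H](C)CO)cc1OC`: 67000 nM in a functional assay on HeLa cells (Homo sapiens) for cytotoxicity, read by WST assay, with a stated time of 48 h; on this read-out lower numbers stand for stronger inhibition and higher numbers for weaker inhibition
- compound 2, `COc1cc(C(c2ccc(O)c(OC)c2)[C@H](CC(C)C)C(C)C)ccc1O`: 8200 nM in this assay

Compound 2 holds the lowest of the two numbers in this assay; compound 1 stands higher by a margin beyond the usual scatter. For the measured compounds named here, no single-point step links the two measured compounds, so only the two values themselves can be compared.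

Compound 3, `COC[C@@H](C)[C@@H](C)C(c1ccc(O)c(OC)c1)c1ccc(O)c(OC)c1`, is the next compound for this assay. Its change from compound 2: 2-(methoxymethyl)-1-methylpropyl in place of 1-isopropyl-3-methylbutyl on a saturated chain carbon bound to two aromatic carbons

A loss of potency beyond the scatter is expected here, since the chain of compound 3 moves toward that of compound 1, which gives 67000 nM in this assay, while the two phenols of compound 2 are kept. The step from compound 2 to compound 3 in this assay is estimated at a 3.0-fold higher number from compound 2 to compound 3 (0.48 log units; beyond the scatter). Compound 3 is expected to give about 25000 nM in this assay, within 8000 nM to 80000 nM.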

Compound 3, half-maximal inhibitory concentration: > 100000 nM
Compound 3 ended at the assay's limit (the forecaster's own chance of this, stated with the estimate: 10%); at least 4.0-fold (0.60 log units) between middle value and limit.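

In this assay compound 3 gives > 100000 nM, which is a limit of the assay and not a number. On the saturated chain carbon bound to two aromatic carbons, 2-(methoxymethyl)-1-methylpropyl in place of 1-isopropyl-3-methylbutyl is a large step, an at least 12-fold higher number from compound 2 to compound 3 (1.08 log units; beyond the scatter), so this position is sensitive to the change of chain even with the two phenols kept. The full size of the step cannot be read, and the figure is only a bound: the limit of > 100000 nM in this assay, at which 1 of the 3 values shown sits.

The entering group differs from the leaving one in both its oxygen and its carbon count, and the compounds shown do not separate the two. From the compounds shown here alone, how an amine or a carboxylic acid in that chain, or a longer all-carbon chain, would read in this assay stays open.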